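The source may report more compounds than this note shows. Statements on the series, on what has been measured and on what is new or still open speak of the compounds shown alone.

Three compounds built on closely related two-ring cores were tested in a functional assay on OVCAR-5 cells (Homo sapiens) for cytotoxicity, read by sulforhodamine B assay, with a stated time of 48 h; a lower number here means that less compound is tolerated, a higher number that more compound is tolerated. Compound 1 `ClCc1ccccc1Cn1cnc2c(Cl)nc(Cl)nc21` gives 5620 nM. Compound 2 `ClCc1ccccc1Cn1cnc2c(Cl)ncnc21` gives 25700 nM, and compound 3 `ClCc1ccccc1Cn1cnc2ncnc(Cl)c21` gives 26900 nM; the values of compound 2 and compound 3 lie within the usual scatter of each other, so they are best read as alike. The cores of compound 2 and compound 3 have the same atoms joined differently; that difference is not broken down here. Going from compound 2 to compound 1, the change is chloro in place of hydrogen on an aromatic carbon, and it gave a 4.6-fold lower number from compound 2 to compound 1 (0.66 log units; beyond the scatter). From the compounds shown here alone, compound 4 `ClCc1ccccc1Cn1cnc2nc(Cl)nc(Cl)c21` is untested; it differs from compound 3 by chloro in place of hydrogen on an aromatic carbon, the same change at the same kind of place. Because compound 1 showed a 4.6-fold lower number from compound 2 to compound 1 (0.66 log units; beyond the scatter), a step of a 4.5-fold lower number from compound 3 to compound 4 (0.65 log units; beyond the scatter) is expected here. Compound 4 is therefore estimated at about 6000 nM, likely between 2500 nM and 14000 nM.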

Compound 4, concentration lethal to 50% of the cells: 28800 nM
Beside the measured number, compound 4's estimate is 4.8-fold (0.68 log units) below it; measured number outside the range, above it.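

In this assay, placing the chloro on the core of compound 3 gave a 1.1-fold higher number from compound 3 to compound 4 (0.03 log units; within the scatter), so the clear step seen on the core of compound 1 did not carry over. Set side by side, the two results differ: the same change on two cores in this assay, a 4.6-fold lower number (0.66 log units; beyond the scatter) from compound 2 to compound 1 and a 1.1-fold higher number (0.03 log units; within the scatter) from compound 3 to compound 4, 4.9-fold (0.69 log units) apart, beyond the scatter of two such steps

In these four compounds, then, the result of this change depends on the core that carries it, but the numbers do not show why, and two cores cannot give a rule for any others. From the compounds shown here alone, it remains open how an amine or a methoxy group in place of this chloro, between two ring nitrogen atoms, would behave on each core.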